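The source may report more compounds than this note shows. Statements on the series, on what has been measured and on what is new or still open speak of the compounds shown alone.

The measured compounds and their values in an assay on isolated protein (Bos taurus) with 5-hydroxytryptamine receptor 1D (Homo sapiens) as the target; a higher number here means a weaker inhibitor, a lower number a stronger inhibitor:

Compound 1, `c1cnc(NCCNCC2CCc3ccccc3O2)nc1`: 31.6 nM
Compound 2, `c1ccc2c(c1)CCC(CNCCCNC1=NCCCC1)O2`: 3.98 nM
Compound 3, `c1ccc2c(c1)CCC(CNCCCNc1ccncn1)O2`: 10 nM

On the three numbers in this assay, compound 3 stands second highest. Its nearest neighbour is compound 2, with a 2.5-fold higher number from compound 2 to compound 3 (0.40 log units; beyond the scatter), a modest step that lies beyond the scatter. Compound 1 gives the highest number of the three, and compound 3 sits a clear way below it; the two differ in more than one place, so only their two values can be set side by side.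

Compound 4, `c1ccc2c(c1)CCC(CNCCCNc1nccs1)O2`, differs from compound 3 in one place: 1,3-thiazol-2-yl in place of pyrimidin-4-yl on an amine nitrogen. Among the compounds with values here, the only measured step that bears on a change at this amine nitrogen is the one from compound 2 to compound 3, where a six-membered aromatic ring with two hetero atoms replaced a six-membered non-aromatic ring with one hetero atom and the number rose by a modest amount. In compound 4 one aromatic ring with two hetero atoms replaces another, which is a smaller kind of change than the one measured. The expectation is therefore a step of a 1.3-fold lower number from compound 3 to compound 4 (0.10 log units; within the scatter) in this assay, within the scatter. Compound 4 is estimated at 8 nM, with a range from 3 nM to 25 nM.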

Compound 4, half-maximal inhibitory concentration: 7.94 nM
The estimate for compound 4 lay 1.0-fold (0.00 log units) above the measured number; the range from low to high includes it.
By their numbers in this assay, from the lowest: compounds 2, 4 and 3 (each within the scatter of the next, the first and the last beyond it); then compound 1.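

In this assay, the exchange of the six-membered pyrimidin-4-yl for the five-membered 1,3-thiazol-2-yl on this amine nitrogen gives a 1.3-fold lower number from compound 3 to compound 4 (0.10 log units; within the scatter) as its step, so at this position the change of aromatic ring size and of hetero atoms makes no difference that the assay can separate from scatter. The non-aromatic ring of compound 2 also no longer stands apart from every aromatic group: a 2.0-fold higher number from compound 2 to compound 4 (0.30 log units; within the scatter) stays within the scatter, unlike the step to the pyrimidin-4-yl compound, while a 4.0-fold lower number from compound 1 to compound 4 (0.60 log units; beyond the scatter) is a larger step that joins a change of ring with a change of chain and so cannot be assigned to either alone. Nothing available explains these numbers.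

What the compounds shown leave open is whether the flat result holds for other groups on this nitrogen, such as a plain phenyl ring, an oxazol-2-yl group or a 1,3-thiazol-2-yl ring carrying a methyl group. Within the data shown here, the effect of the chain alone also stays open, since no pair here tests a longer chain with the same ring on the amine nitrogen.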